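The source may hold more compounds than are shown below. What is called first, only, known or untested is meant among the compounds shown, and "the series" means these compounds.

Measured so far:
Compound 1 `Cc1cccc(CN2CCC(c3noc(CN(C)c4ncc(C(=O)NO)cn4)n3)CC2)c1` gives 54% in an assay on isolated protein for inhibition of protein deacetylase HDAC6 (Homo sapiens), read by fluorescence, with a stated time of 1 h, tested at 100 nM; on this read-out lower numbers stand for less inhibition and higher numbers for more inhibition at the one concentration tested (going by the name of the read-out).
Compound 2 `CN(Cc1nc(C2CCN(Cc3ccc(F)cc3)CC2)no1)c1ncc(C(=O)NO)cn1` gives 65% in this assay.
Compound 3 `CN(Cc1nc(C2CCN(Cc3ccccc3Cl)CC2)no1)c1ncc(C(=O)NO)cn1` gives 55% in this assay.

Compound 3 stands second highest of the three numbers. Its nearest neighbour is compound 1, which sits a number 1 percentage points higher from compound 1 to compound 3 (within the scatter), a gap inside the usual scatter. Compound 2 lies furthest away, with a number 10 percentage points lower from compound 2 to compound 3 (within the scatter), which is also within the scatter. For the measured compounds named here, the one step that reaches beyond the scatter is a number 11 percentage points higher from compound 1 to compound 2 (beyond the scatter), and it is modest.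

Compound 4 `CN(Cc1nc(C2CCN(Cc3ccc(C#N)cc3)CC2)no1)c1ncc(C(=O)NO)cn1` is the next compound. It differs from compound 3 in one place: 4-cyanophenyl in place of 2-chlorophenyl on a saturated chain carbon bound to an amine nitrogen in a ring. The three measured steps all concern what sits on that saturated chain carbon bound to the amine nitrogen in the ring, so all of them bear on the change, and none exceeds a modest size. Going by the values given here, the only group that shares the 4-position pattern with 4-cyanophenyl is the 4-fluorophenyl of compound 2, whose value stands at 65%. Taken together the steps suggest a small rise at most, likely within the scatter, so the expected step is a number 5 percentage points higher from compound 3 to compound 4 (within the scatter). Compound 4 is therefore estimated to give 60%, with a range from 45% to 75%.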

Compound 4, a percentage reported as inhibition, at one concentration (the size of the read-out at that concentration, not a potency): 38%
Beside the measured number, compound 4's estimate is 22 percentage points above it; measured number outside the range, below it.
By their numbers in this assay, from the lowest: compound 4; then compounds 1, 3 and 2 (each within the scatter of the next, the first and the last beyond it).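

For the compounds shown here, the place on a saturated chain carbon bound to an amine nitrogen in a ring proves more sensitive than the first three compounds indicated: in this assay, cyano in place of fluoro on an aromatic carbon gives a number 27 percentage points lower from compound 2 to compound 4 (beyond the scatter) and so exceeds the one step beyond the scatter seen among those compounds. The change also separates 4-cyanophenyl from the other two aryl groups, with a number 17 percentage points lower from compound 3 to compound 4 (beyond the scatter) for its exchange with 2-chlorophenyl and a number 16 percentage points lower from compound 1 to compound 4 (beyond the scatter) for its exchange with 3-methylphenyl, so that 4-fluorophenyl and 4-cyanophenyl, though alike in the way their names place the group, do not read alike. No accompanying measurement bears on what lies behind this drop.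

The compounds shown leave open whether the lower number belongs to the nitrile alone or would also appear with a methoxy group, a carboxylic acid or an amine on the phenyl ring. They also leave open whether a nitrile on the phenyl ring in the other placements seen here, as in 2-cyanophenyl or 3-cyanophenyl, would give a similar reading.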